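The source may report more compounds than this note shows. Statements on the series, on what has been measured and on what is new or still open speak of the compounds shown alone.

The study centres on two measured compounds. Compound 1 `CCOc1ccnc2[nH]c(=O)n(-c3nc(N4CCCNCC4)ccc3Cl)c12` stands apart in an assay for inhibition of protein kinase C theta type (Homo sapiens), read by TR-FRET, with stated times of 5 min and 60 min, in the presence of a further agent that is not named here (a lower number here means a stronger inhibitor, a higher number a weaker inhibitor), where compound 1 gives 0.086 nM. Compound 2 `O=c1[nH]c2ncccc2n1-c1nc(N2CCCNCC2)ccc1F` shares the core but carries no ethoxy group and bears fluoro rather than chloro; in this assay compound 2 gives 100 nM, the higher of the two numbers shown, and the gap from compound 1 lies well beyond the scatter. Because compound 2 differs from compound 1 in two places at once, the two values alone do not show how much of that gap belongs to the halogen.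

Compound 3 `O=c1[nH]c2ncccc2n1-c1nc(N2CCCNCC2)ccc1Cl` isolates one of those two changes: chloro in place of fluoro on an aromatic carbon. Compound 1, which also bears chloro at this position, gives the low number already quoted, so the halogen change is expected to move the number downward, though without the ethoxy group a smaller step than the full gap is expected, estimated as a 6.7-fold lower number from compound 2 to compound 3 (0.82 log units; beyond the scatter). For compound 3 in this assay the estimate is 15 nM, with a range from 2 nM to 80 nM.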

Compound 3, half-maximal inhibitory concentration: 18 nM
Compound 3: middle estimate off by 1.2-fold (0.08 log units), on the low side; measured number inside the range.
By their numbers in this assay, from the lowest: compound 1; then compound 3; then compound 2.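

In this assay, chloro in place of fluoro on the aromatic carbon para to the 1,4-diazepan-1-yl group gives a 5.6-fold lower number from compound 2 to compound 3 (0.74 log units; beyond the scatter) in the absence of the ethoxy group, so the halogen at this position matters on its own, though only modestly. With chloro held constant, hydrogen in place of ethoxy gives a 210-fold higher number from compound 1 to compound 3 (2.32 log units; beyond the scatter) and is the large step of the two, so most of the distance between the two compounds first compared goes with the ethoxy group rather than the halogen. Nothing given here explains why either change moves the number as it does.

As far as these compounds go, whether the halogen step keeps its size when the ethoxy group is present remains open, as both compounds in that step lack it. Also open, from the compounds shown here alone, is whether bromo, methyl or a nitrile on this aromatic carbon would go beyond chloro, and whether methoxy, a longer alkoxy chain or an amine in the place of ethoxy would keep the number as low as it stands for compound 1.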